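Aryl swap on the amide nitrogen of compound 3

The source may hold more compounds than are shown below. What is called first, only, known or untested is meant among the compounds shown, and "the series" means these compounds.

Compound 1 `O=C(CN1CCN(c2nnc(Cc3ccncc3)c3ccccc23)CC1)Nc1cccc(F)c1`: 4.4 nM
Compound 2 `COc1ccc(NC(=O)CN2CCN(c3nnc(Cc4ccccc4)c4ccccc34)CC2)cc1OC`: 32200 nM
Compound 3 `O=C(CN1CCN(c2nnc(Cc3ccccc3)c3ccccc23)CC1)Nc1ccc(F)c(F)c1`: 2750 nM

These numbers come from a functional assay on MDA-MB-231 cells (Homo sapiens) for cytotoxicity, read by MTT assay, with a stated time of 72 h; a higher number here means a weaker inhibitor, a lower number a stronger inhibitor. Compound 3, at 2750 nM, holds the second highest of the three numbers, with compound 2 higher and compound 1 far lower. Compound 4 `Cc1cccc(Cl)c1NC(=O)CN1CCN(c2nnc(Cc3ccccc3)c3ccccc23)CC1` keeps the rest of compound 3 and changes one group: 2-chloro-6-methylphenyl in place of 3,4-difluorophenyl on an amide-type nitrogen. Within the data shown here, the only measured step at this place is a 12-fold lower number from compound 2 to compound 3 (1.07 log units; beyond the scatter), a large one, so a change here can move the number well beyond the scatter. That step does not involve the entering group and gives no firm direction. A moderate step is therefore expected, leaning towards a higher number: a 2.2-fold higher number from compound 3 to compound 4 (0.34 log units; beyond the scatter). Compound 4 is estimated at 6000 nM, with an expected range of 1000 nM to 35000 nM.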

Compound 4, half-maximal inhibitory concentration: 3920 nM
The estimate for compound 4 lay 1.5-fold (0.18 log units) above the measured number; the range from low to high includes it.
By their numbers in this assay, from the lowest: compound 1; then compounds 3 and 4 (each within the scatter of the next); then compound 2.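

Replacing 3,4-difluorophenyl with 2-chloro-6-methylphenyl on the amide-type nitrogen gives a 1.4-fold higher number from compound 3 to compound 4 (0.15 log units; within the scatter), so this measurement does not separate the two groups. Replacing 3,4-dimethoxyphenyl with the same group gives an 8.2-fold lower number from compound 2 to compound 4 (0.91 log units; beyond the scatter), which sets compound 2 apart from both compound 3 and compound 4. No measured evidence accounts for these differences. Going by these compounds, it remains open whether a cyclohexyl group or a longer alkyl chain on this nitrogen would stay near compound 3 and compound 4. Compound 1 differs from them in more than one place. Its number says nothing separate about this position.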